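Aryl Exchange on the Triazole Nitrogen of Compound 3

The source may report more compounds than this note shows. Statements on the series, on what has been measured and on what is new or still open speak of the compounds shown alone.

The series shares a spiro core carrying a nitrile, an amine and a triazole-methyl arm, and differs in the aryl group on the triazole nitrogen. Compound 1 `Cc1cccc(-n2nncc2CN2C(=O)C3(C(C#N)=C(N)Oc4c3c3nc5ccccc5nc3c3ccccc43)c3ccccc32)c1` gives 39600 nM in a functional assay on A549 cells (Homo sapiens) for antiproliferative activity, read by MTT assay, with a stated time of 48 h; a higher number here means a weaker inhibitor, a lower number a stronger inhibitor. Compound 2 `N#CC1=C(N)Oc2c(c3nc4ccccc4nc3c3ccccc23)C12C(=O)N(Cc1cnnn1-c1ccc(Cl)c(Cl)c1)c1ccccc12` gives only a limit in this assay, > 50000 nM. Compound 3 `COc1ccccc1-n1nncc1CN1C(=O)C2(C(C#N)=C(N)Oc3c(N)cc4nc5ccccc5nc4c32)c2ccccc21`, which also carries an amine on its fused ring system, gives 37500 nM in this assay. Compound 3 and compound 1 lie within the scatter of each other; the third value shown is a limit rather than a number, so compound 3 cannot be ranked against it.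

Compound 4 `Cc1ccc(-n2nncc2CN2C(=O)C3(C(C#N)=C(N)Oc4c(N)cc5nc6ccccc6nc5c43)c3ccccc32)cc1Cl` differs from compound 3 by 3-chloro-4-methylphenyl in place of 2-methoxyphenyl on an aromatic nitrogen. Within the data shown here, the one measured step of the same kind is an aryl exchange on that nitrogen, an at least 1.2-fold higher number from compound 1 to compound 2 (0.10 log units; that floor lies within the scatter), whose floor lies within the scatter and which ends at a limit (the limit of > 50000 nM in this assay, at which 1 of the 3 values shown sits). An aryl change at this position therefore gave no clear movement, and compound 4 is expected to show no step beyond the scatter, a 1.1-fold higher number from compound 3 to compound 4 (0.03 log units; within the scatter). Compound 4 is accordingly estimated at 40000 nM in this assay, within 22000 nM to 70000 nM, with a fair chance that only a limit is recorded.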

Compound 4, half-maximal inhibitory concentration: 11800 nM
The estimate for compound 4 lay 3.4-fold (0.53 log units) above the measured number; measured number outside the range, below it.
By their numbers in this assay, from the lowest: compound 4; then compounds 3 and 1 (each within the scatter of the next). At a limit, above all of these: compound 2.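

In this assay, the exchange of 2-methoxyphenyl for 3-chloro-4-methylphenyl on the aromatic nitrogen gives a 3.2-fold lower number from compound 3 to compound 4 (0.50 log units; beyond the scatter), so an aryl change at this position can move the number beyond the scatter. The earlier step, an at least 1.2-fold higher number from compound 1 to compound 2 (0.10 log units; that floor lies within the scatter), could not show this, since its floor lies within the scatter and it points the other way, towards a higher number. The result therefore shows that the choice of aryl group on this nitrogen matters on the core of compound 3, though nothing measured here accounts for the step.

The exchange removes the methoxy group and brings in a chlorine and a methyl group at once, so the compounds shown leave open which of these carries the step, and whether 3-chlorophenyl or 4-methylphenyl alone would give the same number. They also leave open whether the step would hold on the core of compound 1, which lacks the amine on the fused ring system, and what a benzyl group or a pyridyl ring would do on this nitrogen.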